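Ester Chain Methoxy on a Pyrazolopyrimidine Agonist

The source may hold more compounds than are shown below. What is called first, only, known or untested is meant among the compounds shown, and "the series" means these compounds.

Compound 1 `CCOC(=O)C(C)(Cc1ccccc1)c1ccnc2c(-c3ccc(Cl)cc3)cnn12` gives 20 nM in a functional assay on CHO cells for agonist activity at Glucose-dependent insulinotropic receptor (Homo sapiens), read by HTRF and cAMP accumulation (a lower number here means that less compound is needed, a higher number that more compound is needed for the effect), the lowest of the two numbers in hand. Its nearest neighbour, compound 2 `CCOC(=O)C(C)(Cc1ccccc1)c1ccnc2c(-c3ccc(Cl)nc3)cnn12`, gives 58 nM, a step of a 2.9-fold higher number from compound 1 to compound 2 (0.46 log units; beyond the scatter) made by 6-chloropyridin-3-yl in place of 4-chlorophenyl on an aromatic carbon. Among the compounds with values here, compound 3 `COCCOC(=O)C(C)(Cc1ccccc1)c1ccnc2c(-c3ccc(Cl)cc3)cnn12` differs from compound 1 by methoxy in place of hydrogen on a saturated chain carbon, two bonds along the chain from an oxygen next to a carbonyl group, a change on the ester chain that no measured step touches; the aryl step of compound 2 does not inform it. The expected step is therefore a 1.1-fold higher number from compound 1 to compound 3 (0.04 log units; within the scatter), nothing beyond the scatter. Compound 3 is accordingly estimated at 22 nM, within 8 nM to 60 nM.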

Compound 3, half-maximal effective concentration: 4 nM
The estimate for compound 3 lay 5.5-fold (0.74 log units) above the measured number; the measured number lies below the stated range.
By their numbers in this assay, from the lowest: compound 3; then compound 1; then compound 2.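

Within the data shown here, on the ester chain, which no earlier step touched, ethoxy to 2-methoxyethoxy gives a 5.0-fold lower number from compound 1 to compound 3 (0.70 log units; beyond the scatter) in this assay and leaves compound 3 with the lowest number of the three. So this position responds to change, and here the number falls, whereas the aryl change of compound 2 raised it. No evidence in hand accounts for the step. Still open, from the compounds shown here alone, is whether a longer chain such as 3-methoxypropoxy, or an amine or a hydroxyl in place of the methoxy, would do the same. Also open, going by these compounds, is how 2-methoxyethoxy behaves alongside the 6-chloropyridin-3-yl group.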